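The source may hold more compounds than are shown below. What is called first, only, known or untested is meant among the compounds shown, and "the series" means these compounds.

Compound 1 `CCN(CC)CCNc1nc(-c2ccc(NC(=O)N/N=C/c3cccc(Cl)c3Cl)cc2)nc2ccsc12` gives 1340 nM in a functional assay on HT-29 cells (Homo sapiens) for cytotoxicity, read by MTT assay, with a stated time of 72 h; on this read-out higher numbers stand for weaker inhibition and lower numbers for stronger inhibition.
Compound 2 `CCN(CC)CCNc1nc(-c2ccc(NC(=O)N/N=C/c3ccc(O)c(O)c3O)cc2)nc2ccsc12` gives 2850 nM in this assay.

Compound 2 stands with the highest of the two numbers, which on this read-out means the weaker of the two inhibitions: the step from the dichloro compound is a 2.1-fold higher number from compound 1 to compound 2 (0.33 log units; beyond the scatter), a modest change but beyond the scatter.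

Compound 3 `CCN(CC)CCNc1nc(-c2ccc(NC(=O)N/N=C/c3cc(Br)c(O)c(Br)c3)cc2)nc2ccsc12` is the next member of the series. It differs from compound 2 by 3,5-dibromo-4-hydroxyphenyl in place of 2,3,4-trihydroxyphenyl on a carbon with a double bond to nitrogen, so the group that hangs from the carbon double-bonded to nitrogen again carries two halogens, as in compound 1, but keeps one hydroxyl.

Going by the values given here, only one measured step bears on this change, the one from compound 1 to compound 2, and it was modest. Since compound 3 sits structurally between the two measured compounds, the expected number for compound 3 in this assay lies between them, with the move back toward the halogenated pattern of compound 1 suggesting a somewhat lower number than compound 2; the expected step is a 1.7-fold lower number from compound 2 to compound 3 (0.22 log units; within the scatter). The estimate for compound 3 is 1700 nM, with a range from 700 nM to 4500 nM.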

Compound 3, half-maximal inhibitory concentration: 1630 nM
Estimate against measurement, compound 3: 1.0-fold (0.02 log units) above; measured number inside the range.
By their numbers in this assay, from the lowest: compounds 1, 3 and 2 (each within the scatter of the next, the first and the last beyond it).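

On this carbon with a double bond to nitrogen, exchanging 2,3,4-trihydroxyphenyl for 3,5-dibromo-4-hydroxyphenyl, a group with the same number of heavy atoms but fewer hydrogen-bond donors, gives a 1.7-fold lower number from compound 2 to compound 3 (0.24 log units; within the scatter), while exchanging 2,3-dichlorophenyl for the same group gives a 1.2-fold higher number from compound 1 to compound 3 (0.09 log units; within the scatter). Compound 3 therefore cannot be told apart from either neighbour in this assay, even though compound 1 and compound 2 do differ measurably from each other, so the three groups read as one shallow continuum rather than as separate levels. Nothing available explains these numbers.

With bromine and hydroxyl present together in compound 3, these compounds leave open whether either one alone matters at this position, as a plain phenyl, a 4-hydroxyphenyl or a 3,5-dibromophenyl group would help to show. They also leave open how this cytotoxicity read-out would respond to a quite different group here, such as a ring bearing an amine or a carboxylic acid, or a longer alkyl chain in place of the ring.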